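Replacing the dichlorophenyl amide by a cyclohexenyl amide

This account rests on a few compounds, and the source may have more. Where it says the series, first, only, none or still open, it means among the compounds named here.

Compound 3 `O=C(Nc1cc(-c2ccccc2)nn1-c1ccccc1)c1ccc(Cl)c(Cl)c1` is the compound with the lowest number among the measured values in an assay on HEK293 cells for displacement of a labelled ligand from metabotropic glutamate receptor 5 (Rattus norvegicus) (on this read-out lower numbers stand for stronger inhibition and higher numbers for weaker inhibition), where compound 3 gives 160 nM. Its nearest neighbour is compound 1 `COc1ccc(C(=O)Nc2cc(-c3ccccc3)nn2-c2ccccc2)cc1`, which in this assay gives 420 nM; the change from 4-methoxyphenyl to 3,4-dichlorophenyl on the carbonyl carbon gave a 2.6-fold lower number from compound 1 to compound 3 (0.42 log units; beyond the scatter). Compound 2 `NC(=O)c1ccc(C(=O)Nc2cc(-c3ccccc3)nn2-c2ccccc2)cc1` reaches only a limit of the assay, > 10000 nM. That limit is the limit of > 10000 nM in this assay, at which 1 of the 3 values shown sits. Placing carbamoyl in place of methoxy gave an at least 23-fold higher number from compound 1 to compound 2 (1.37 log units; beyond the scatter), and the move from the carbamoyl compound to the dichlorophenyl compound gave an at least 62-fold lower number from compound 2 to compound 3 (1.79 log units; beyond the scatter).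

Compound 4 `O=C(Nc1cc(-c2ccccc2)nn1-c1ccccc1)C1=CCCCC1` changes the group on the same carbonyl carbon: cyclohex-1-en-1-yl in place of 3,4-dichlorophenyl on a carbonyl carbon. All three measured steps alter this group, so they bear on the new step; two of them were modest, one large. None of them replaces the aromatic ring itself by a non-aromatic one, so the closest guide is the modest range seen between compound 1 and compound 3. The expected step is therefore a 3.1-fold higher number from compound 3 to compound 4 (0.49 log units; beyond the scatter), toward a higher number, with the direction less certain than its size. Compound 4 is estimated at 500 nM, within 150 nM to 2500 nM.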

Compound 4, inhibition constant: 4470 nM
For compound 4 the middle estimate is 8.9-fold (0.95 log units) below the measured one; the whole stated range lies below it.
By their numbers in this assay, from the lowest: compound 3; then compound 1; then compound 4. At a limit, above all of these: compound 2.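

In this assay compound 4 carries the only non-aromatic ring on this carbonyl carbon among the compounds shown, and this change gives a 28-fold higher number from compound 3 to compound 4 (1.45 log units; beyond the scatter) and an 11-fold higher number from compound 1 to compound 4 (1.03 log units; beyond the scatter); both steps are large, whereas the exchange between the two substituted phenyl groups in compound 1 and compound 3 was modest. For the compounds shown here, the cyclohex-1-en-1-yl group still keeps a measurable number, with an at least 2.2-fold lower number from compound 2 to compound 4 (0.34 log units; beyond the scatter) and the 4-carbamoylphenyl group remaining the only group here that reaches the end of the read-out. That step starts from compound 2, whose value is a limit of the assay and not a number, so it gives only a bound: the limit of > 10000 nM in this assay, at which 1 of the 4 values shown sits.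

The compounds shown leave open whether the large step goes with the non-aromatic ring or with the departure of the two chlorine atoms, and how a plain phenyl or a saturated cyclohexyl group would read on this carbonyl carbon would separate the two. Also open, going by these compounds, is how an amine or a carboxylic acid on the phenyl ring would compare with the carbamoyl group of compound 2.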